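Swapping a methoxyphenyl for a piperidinylmethyl on a nucleoside core

A few compounds are considered here, and "the series" means these few. Any claim that something is new, unique, unknown or untested is made for them only; others in the source may bear on it.

Measured compounds:
- compound 1, `COc1ccc(Cn2c(=O)n(C3OC(CO)[C@@H](O)[C@H]3O)c3nc(N)nc(O)c32)cc1`: 14%
- compound 2, `C=CCSc1nc2c(O)nc(N)nc2n1C1OC(CO)[C@@H](O)[C@H]1O`: 57%
- compound 3, `C=CCn1c(=O)n(C2CN(CCCC)CC(CO)O2)c2nc(N)nc(O)c21`: 52%

All three compounds share a purine-like core carrying a sugar, and were tested in a functional assay on the whole organism with Mus musculus as the target; a lower number here means a smaller maximal response, a higher number a larger maximal response. In this assay compound 1 gives 14%, the lowest of the three numbers. Compound 3 gives 52% and compound 2 gives 57%; both stand well above compound 1, beyond the scatter, while compound 2 and compound 3 lie within the scatter of each other. For the measured compounds named here, compound 2 and compound 3 each differ from compound 1 in more than one place, so no single step between measured compounds is available.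

The unmeasured compound 4, `Nc1nc(O)c2c(n1)n(C1OC(CO)[C@@H](O)[C@H]1O)c(=O)n2CCN1CCCCC1`, departs from compound 1 by one change: (piperidin-1-yl)methyl in place of 4-methoxyphenyl on a saturated chain carbon bound to an aromatic nitrogen. The group that leaves carries an aromatic ring, the group that enters a saturated ring with a nitrogen. Going by the values given here, no measured pair shows the effect of this exchange on its own, so the size of the step in this assay is uncertain. Given that compound 1 gives 14% while compound 2 and compound 3, which vary the side chain in other ways, both stand beyond the scatter above it, a rise is expected, but its extent is open. Compound 4 is therefore estimated at 35%, within a range of 10% to 65%, which is an expected step of a number 21 percentage points higher from compound 1 to compound 4 (beyond the scatter).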

Compound 4, largest response reached (reported as maximal response), in percent of the reference or control that the assay uses: 0%
For compound 4 the middle estimate is 35 percentage points above the measured one, and the stated range ends above it.
By their numbers in this assay, from the lowest: compound 4; then compound 1; then compounds 3 and 2 (each within the scatter of the next).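

In this assay, for the compounds shown here, the exchange of 4-methoxyphenyl for (piperidin-1-yl)methyl on a saturated chain carbon bound to an aromatic nitrogen gives the first single-change reading at this position, a number 14 percentage points lower from compound 1 to compound 4 (beyond the scatter). The group at this place therefore bears on the maximal response, and in this pair, removing the aromatic ring and bringing in a saturated ring with a nitrogen lowers the response rather than raising it. No measurement of any property of these groups accompanies the step, so the data offer no explanation for it.

This one pair cannot separate the loss of the 4-methoxybenzyl group from the gain of the 2-(piperidin-1-yl)ethyl group, and an unsubstituted benzyl, a 2-(morpholin-4-yl)ethyl or an open-chain 2-(dimethylamino)ethyl at the same place would help tell these two effects apart. Going by these compounds, it also remains open whether the same exchange lowers the response on a compound that differs from compound 1 elsewhere, since a single pair on a single core shows no general pattern.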